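Bromo in Place of Hydrogen on Compound 2

The compounds below may be only part of what the source reports. "The series", "measured", "known", "first", "only" and "open" are said of these compounds alone.

Among the measured compounds shown here, compound 2, `O=C(NC1(C(=O)O)CCCCC1)c1cccc2cc(-c3ccc(Cl)cc3)oc12`, is the one compound in this set with a plain number in an assay on isolated protein for inhibition of endoplasmic reticulum aminopeptidase 1 (Homo sapiens), read by mass spectrometry, with stated times of 15 min and 25 min, tested at 10 uM; on this read-out lower numbers stand for less inhibition and higher numbers for more inhibition at the one concentration tested (going by the name of the read-out): in that assay compound 2 gives 2.17%. Compound 1, `CC(C)(NC(=O)c1cccc2c(Br)c(-c3ccc(Cl)cc3)oc12)C(=O)O`, is reported only as a limit in this assay, at > 30%, and this is not a number. Compound 3, `O=C(NC1(C(=O)O)CCCCC1)c1cc(F)cc2cc(-c3ccc(Cl)cc3)oc12`, carries no result in this assay, recorded as "not determined" (no result reported). Compound 4, `O=C(NC1(C(=O)O)CCCCC1)c1cccc2c(Br)c(-c3ccc(Cl)cc3)oc12`, has not yet been tested. It differs from compound 2 in a single place: bromo in place of hydrogen on an aromatic carbon. For the measured compounds named here, no step between two measured compounds covers this change. Compound 1 bears the same bromo on the same core and sits at the limit of > 30% in this assay, at which 1 of the 3 values shown sits. On that basis the change is expected to raise inhibition well beyond the scatter rather than leave it unchanged. Compound 4 is therefore expected to give about 35% in this assay, within a range from 10% to 65%. That expectation amounts to a number 32.8 percentage points higher from compound 2 to compound 4 (beyond the scatter) in this assay.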

Compound 4, a percentage reported as inhibition, at one concentration (the size of the read-out at that concentration, not a potency): 4.37%
Compound 4: middle estimate off by 30.6 percentage points, on the high side; measured number outside the range, below it.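

In this assay, bromo in place of hydrogen on the aromatic carbon next to the ring atom that bears a 4-chlorophenyl group makes no clear difference when the amide-type nitrogen carries 1-carboxycyclohexyl: the step is a number 2.2 percentage points higher from compound 2 to compound 4 (within the scatter). With that bromo held constant, the group on the nitrogen does make a difference, since 1-carboxycyclohexyl in place of 1-carboxy-1-methylethyl gives a number at least 25.6 percentage points lower from compound 1 to compound 4 (beyond the scatter), so the bromo alone does not account for the reading of compound 1. The reading of compound 1 remains a limit and not a number: the limit of > 30% in this assay, at which 1 of the 4 values shown sits.

The compounds shown leave open how hydrogen in place of bromo would read alongside 1-carboxy-1-methylethyl, so it remains unsettled whether the bromo counts with that group. Also open, from the compounds shown here alone, is how a methoxy group or an amine on the same aromatic carbon would read.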